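Aryl ether to methylsulfonyl in the imidazoline series

A few compounds are considered here, and "the series" means these few. Any claim that something is new, unique, unknown or untested is made for them only; others in the source may bear on it.

Three compounds of the series carry a measured intrinsic activity in an assay on CHO cells with Alpha-2B adrenergic receptor (Homo sapiens) as the target; a higher number here means a larger maximal response, a lower number a smaller maximal response. Compound 1 `CCOc1ccccc1OC(C)C1=NCCN1` gives 0.5, compound 2 `CC(C)Oc1ccccc1OC(C)C1=NCCN1` gives 0.5 and compound 3 `C=C(C)c1ccccc1OC(C)C1=NCCN1` gives 0.4. Compound 2 stands level with compound 1 at the digits shown, the two together the highest of the three numbers, and the step of no change at the digits printed from compound 1 to compound 2 (within the scatter) is flat. The aromatic substituent has been exchanged once: a number 0.10 lower from compound 1 to compound 3 (within the scatter) and a number 0.10 lower from compound 2 to compound 3 (within the scatter) both stay inside the scatter.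

Compound 4 `CC(Oc1ccccc1S(C)(=O)=O)C1=NCCN1` is not yet measured. It differs from compound 2 by methylsulfonyl in place of isopropoxy on an aromatic carbon. Within the data shown here, no measured step replaces an aromatic ether with a methylsulfonyl, so the only guide is that the one exchange of the aromatic substituent seen so far, a number 0.10 lower from compound 2 to compound 3 (within the scatter), stayed within the scatter. The step a number 0.10 lower from compound 2 to compound 4 (within the scatter) is therefore expected to be small, at most a slight drop. Compound 4 is estimated at 0.4, with a range from 0.2 to 0.6.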

Compound 4, intrinsic activity: the largest response reached, as a fraction of the reference agonist's: 0.45
Compound 4: the middle estimate sits 0.050 below what was measured, and the stated range covers the measured number.
By their numbers in this assay, from the lowest: compounds 3, 4, 1 and 2 (each within the scatter of the next).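

In this assay, the step a number 0.050 lower from compound 2 to compound 4 (within the scatter) and the step a number 0.050 lower from compound 1 to compound 4 (within the scatter) show that this aromatic carbon also accepts methylsulfonyl, a group with sulfur, two double bonds and two hydrogen-bond acceptors, where isopropoxy has one. The step a number 0.050 higher from compound 3 to compound 4 (within the scatter) extends this to the exchange with 1-methylethenyl, so all four substituents at this position now give maximal responses within the scatter of one another. No measured information bears on why the maximal response holds across these exchanges.

Still open, going by these compounds, is whether this flat picture persists with an amine, a carboxylic acid or a longer chain on the same aromatic carbon. Also open, on these data alone, is whether methylsulfonyl would behave alike on a different carbon of the aromatic ring.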